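Aryl swap on the piperazine nitrogen of compound 2

The compounds below may be only part of what the source reports. "The series", "measured", "known", "first", "only" and "open" are said of these compounds alone.

In an assay on CHO cells for displacement of a labelled ligand from 5-hydroxytryptamine receptor 7 (Homo sapiens) (on this read-out lower numbers stand for stronger inhibition and higher numbers for weaker inhibition), compound 2 `COc1ccccc1N1CCN(CCCN(CC2CCCCC2)S(=O)(=O)c2cccc3cccnc23)CC1` gives 24 nM, the lowest of the two measured numbers. Among the measured compounds shown here, compound 1 `COc1ccccc1N1CCN(CCCN(CC2CCCCC2)S(=O)(=O)c2ccc3ccccc3c2)CC1` gives 500 nM in this assay; the step of a 21-fold lower number from compound 1 to compound 2 (1.32 log units; beyond the scatter) is the only measured step, and it concerns the group on the sulfonyl sulfur. Compound 3 `O=S(=O)(c1cccc2cccnc12)N(CCCN1CCN(c2ccc(Cl)c(Cl)c2)CC1)CC1CCCCC1` differs from compound 2 elsewhere: 3,4-dichlorophenyl in place of 2-methoxyphenyl on an amine nitrogen in a ring. For the measured compounds named here, no measured step touches the amine nitrogen in the ring, so the data give neither a direction nor a size for this change, and the expectation rests on the number for compound 2 alone. The step of a 1.7-fold higher number from compound 2 to compound 3 (0.22 log units; within the scatter) is estimated as none beyond the scatter, with a wide range to cover the absence of any comparable step. Compound 3 is expected to give 40 nM in this assay, with a range from 8 nM to 200 nM.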

Compound 3, half-maximal inhibitory concentration: 2300 nM
The estimate for compound 3 lay 58-fold (1.76 log units) below the measured number; the whole stated range lies below it.
By their numbers in this assay, from the lowest: compound 2; then compound 1; then compound 3.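

In this assay, the aryl group on the amine nitrogen in the ring proves to be a sensitive position: 3,4-dichlorophenyl in place of 2-methoxyphenyl gives a 96-fold higher number from compound 2 to compound 3 (1.98 log units; beyond the scatter), a large step beyond the scatter. Quinolin-8-yl on the sulfonyl sulfur is present on both sides of this step, so that group alone does not secure a low number, and the value of compound 2 also depends on the aryl group on this nitrogen. Nothing at hand accounts for the size of this step.

Open, as far as these compounds go, is whether the step follows the loss of the methoxy group or the arrival of the two chlorines, since this single change carries both; an unsubstituted phenyl or a 2-chlorophenyl on the same nitrogen would separate them. Also open, from the compounds shown here alone, is whether the same aryl swap would move the number similarly with naphthalen-2-yl on the sulfonyl sulfur.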